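Swapping the Aryl Group on a Shared Core

The source may hold more compounds than are shown below. What is called first, only, known or untested is meant among the compounds shown, and "the series" means these compounds.

In a functional assay on T47D cells (Homo sapiens) for inhibition, read by sulforhodamine B assay, with a stated time of 48 h, tested at 10 uM (on this read-out higher numbers stand for more inhibition at the one concentration tested (going by the name of the read-out) and lower numbers for less inhibition), three compounds have been measured. Compound 1 `c1ccc(-c2cn3ccnc3c(-c3ccc4ncn(C5CCCCC5)c4c3)n2)cc1` gives -11.1%. Compound 2 `Brc1ccc(-c2cn3ccnc3c(-c3ccc4ncn(C5CCCCC5)c4c3)n2)cc1` gives 55%. Compound 3 `COc1ccccc1-c1cn2ccnc2c(-c2ccc3ncn(C4CCCCC4)c3c2)n1` gives 36.6%.

Compound 3 thus stands second highest of the three: the step of a number 18.4 percentage points lower from compound 2 to compound 3 (beyond the scatter) separates it from compound 2, and the step of a number 47.7 percentage points higher from compound 1 to compound 3 (beyond the scatter) from compound 1. Compound 4 `FC(F)(F)c1cccc(-c2cn3ccnc3c(-c3ccc4ncn(C5CCCCC5)c4c3)n2)c1` differs from compound 3 in one place: 3-(trifluoromethyl)phenyl in place of 2-methoxyphenyl on an aromatic carbon. Going by the values given here, two steps bear on this. The steps of a number 66.1 percentage points higher from compound 1 to compound 2 (beyond the scatter) and a number 47.7 percentage points higher from compound 1 to compound 3 (beyond the scatter) were both large, so a substituted phenyl has so far sat well above the bare one, while exchanging one substituted phenyl for another gave only the modest step of a number 18.4 percentage points lower from compound 2 to compound 3 (beyond the scatter). Compound 4 is therefore expected to stay near compound 3, with a step of a number 5.4 percentage points higher from compound 3 to compound 4 (within the scatter) within the scatter. The estimate for compound 4 is 42%, ranging from 15% to 68%.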

Compound 4, a percentage reported as inhibition, at one concentration (the size of the read-out at that concentration, not a potency): 52.2%
For compound 4 the middle estimate is 10.2 percentage points below the measured one; low and high end bracket the measured number.
By their numbers in this assay, from the lowest: compound 1; then compound 3; then compounds 4 and 2 (each within the scatter of the next).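

A third kind of substituted phenyl also sits far above the bare phenyl (with a number 63.3 percentage points higher from compound 1 to compound 4 (beyond the scatter)), so all three substituted phenyls shown read higher at this position. The choice of substituted phenyl still matters: 3-(trifluoromethyl)phenyl reads above 2-methoxyphenyl (with a number 15.6 percentage points higher from compound 3 to compound 4 (beyond the scatter)) but cannot be told apart from 4-bromophenyl (with a number 2.8 percentage points lower from compound 2 to compound 4 (within the scatter)). No supporting data explain these differences. From the compounds shown here alone, the substituent and its place on the ring change together in these compounds, so their separate contributions remain open. Going by these compounds, how a phenyl carrying an amine or a carboxylic acid would read also remains open.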